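Triazolyl glycosides on HeLa cells: chloromethyl to bis(hydroxymethyl)

A few compounds are considered here, and "the series" means these few. Any claim that something is new, unique, unknown or untested is made for them only; others in the source may bear on it.

Measured compounds:
compound 1 `CC(=O)N[C@@H]1[C@@H](OC(C)=O)[C@H](OC(C)=O)[C@@H](COC(C)=O)O[C@H]1n1cc(CCl)nn1` 20 ug/mL
compound 2 `CC(=O)N[C@@H]1[C@@H](OC(C)=O)[C@H](OC(C)=O)[C@@H](COC(C)=O)O[C@H]1n1nncc1CCl` 25 ug/mL

In a functional assay on HeLa cells (Homo sapiens), read by colorimetric assay, with a stated time of 72 h (on this read-out higher numbers stand for an effect only at larger amounts of compound and lower numbers for an effect already at smaller amounts), compound 2 gives the higher of the two numbers, though its step from compound 1, a 1.3-fold higher number from compound 1 to compound 2 (0.10 log units; within the scatter), stays within the scatter. Compound 3 `CC(=O)N[C@@H]1[C@@H](OC(C)=O)[C@H](OC(C)=O)[C@@H](COC(C)=O)O[C@H]1n1nnc(CO)c1CO` carries 4,5-bis(hydroxymethyl)-1H-1,2,3-triazol-1-yl in place of 5-(chloromethyl)-1H-1,2,3-triazol-1-yl on a saturated ring carbon. Among the compounds with values here, no measured step touches this change: the single step so far swaps the position of a chloromethyl group, not its identity, so it gives no guide to direction or size. Compound 3 is therefore expected near compound 2, a 1.6-fold higher number from compound 2 to compound 3 (0.20 log units; within the scatter), with wide uncertainty. The estimate for compound 3 is 40 ug/mL, between 15 ug/mL and 120 ug/mL.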

Compound 3, concentration for half-maximal effect: > 100 ug/mL
Compound 3: a limit, no number (the forecaster's own chance of this, stated with the estimate: 25%); middle value at least 2.5-fold (0.39 log units) away from the limit.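

In this assay compound 3 gives > 100 ug/mL, a limit of the assay and not a number. Unlike the shift of chloromethyl, the change to 4,5-bis(hydroxymethyl)-1H-1,2,3-triazol-1-yl at this position gives steps beyond the scatter: an at least 4.0-fold higher number from compound 2 to compound 3 (0.60 log units; beyond the scatter) and an at least 5.0-fold higher number from compound 1 to compound 3 (0.69 log units; beyond the scatter). Both steps are lower bounds, not sizes: the limit of > 100 ug/mL in this assay, at which 1 of the 3 values shown sits.

As far as these compounds go, the change removes chloromethyl and adds two hydroxymethyl groups at once, and which part carries the step stays open. A lone hydroxymethyl or an aminomethyl group at the same place would bear on that.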